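Acyl variation on the piperidine, assessed for receptor binding

The source may report more compounds than this note shows. Statements on the series, on what has been measured and on what is new or still open speak of the compounds shown alone.

Compound 1 `CCN(CC)S(=O)(=O)c1ccc(NC(=O)c2ccccc2)c2ccccc12` reaches only the limit of the assay in an assay on L1.2 cells for binding affinity to C-C chemokine receptor type 8 (Homo sapiens) (a higher number here means a weaker inhibitor, a lower number a stronger inhibitor), giving > 30000 nM. Compound 2 `CCOC(=O)N1CCC(NS(=O)(=O)c2ccc(NC(=O)c3ccccc3)c3ccccc23)CC1` gives 0.17 nM in this assay, while compound 3 `CCC(=O)N1CCC(NS(=O)(=O)c2ccc(NC(=O)c3ccccc3C)c3ccccc23)CC1` gives 2.5 nM, the higher of the two numbers and a gap beyond the scatter. Compound 4 `Cc1ccccc1C(=O)Nc1ccc(S(=O)(=O)NC2CCN(C(=O)CO)CC2)c2ccccc12` differs from compound 3 by hydroxy in place of methyl on a saturated chain carbon bound to a carbonyl carbon. Going by the values given here, no measured pair carries this change, so its effect is unknown from the series itself. The expectation is that the step from compound 3 to compound 4, a 1.2-fold higher number from compound 3 to compound 4 (0.08 log units; within the scatter), stays within the scatter, with no clear direction. Compound 4 is therefore expected at 3 nM in this assay, within a range from 1 nM to 10 nM.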

Compound 4, inhibition constant: 5.4 nM
Estimate against measurement, compound 4: 1.8-fold (0.26 log units) below; low and high end bracket the measured number.
By their numbers in this assay, from the lowest: compound 2; then compound 3; then compound 4. At a limit, above all of these: compound 1.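

In this assay, going by these compounds alone, the change from propanoyl to (hydroxymethyl)carbonyl gives a 2.2-fold higher number from compound 3 to compound 4 (0.33 log units; beyond the scatter) and is the first comparison that differs in one place only. This position therefore accepts hydroxy at a modest cost, on this one pair. No measurement shown gives a cause for the step. Open, from the compounds shown here alone, is how an amine or a carboxylic acid on this same carbon would read, and whether a longer chain carrying the hydroxy would keep the number of compound 4 or move it.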